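Tetrazole for Carboxylic Acid on Two Related Cores

The source may hold more compounds than are shown below. What is called first, only, known or untested is meant among the compounds shown, and "the series" means these compounds.

Measured compounds:
compound 1 `O=C(O)c1ccc(COc2ccc(CNC(=O)[C@@H]3CCC(=O)N3Cc3ccc(F)cc3)cc2)cc1`, > 5000 nM
compound 2 `O=C(NCc1ccc(OCc2ccc(-c3nn[nH]n3)cc2)cc1)[C@@H]1CCC(=O)N1Cc1ccc(F)cc1`, > 5000 nM
compound 3 `O=C(O)c1ccc(COc2ccc(CN3CCC[C@H]3C(=O)NCc3ccccc3)cc2)cc1`, > 5000 nM

In an assay on HEK293 cells for inhibition of Ataxin-2 (Mus musculus), read by fluorescence and Amplex Red (on this read-out lower numbers stand for stronger inhibition and higher numbers for weaker inhibition), compound 1 reaches only the limit of the assay, > 5000 nM, not a number. Compound 2 likewise sits at the limit, > 5000 nM. Compound 3 also gives a limit, > 5000 nM. The change from compound 1 to compound 2 is 2H-tetrazol-5-yl in place of carboxy on an aromatic carbon, and the step it made is a step that the two limits leave unreadable from compound 1 to compound 2; the two limits hide its size, as the limit of > 5000 nM in this assay, at which 3 of the 3 values shown sit, shows. Compound 4 `O=C(NCc1ccccc1)[C@@H]1CCCN1Cc1ccc(OCc2ccc(-c3nn[nH]n3)cc2)cc1` carries the same change on the core of compound 3, namely (2H-tetrazol-5-yl in place of carboxy on an aromatic carbon). The difference between the two cores is not broken down here. For compound 4 the expected step from compound 3 is a step that the limit leaves unreadable from compound 3 to compound 4, resting on the limit seen for compound 3 at > 5000 nM. Compound 4 is estimated at 8000 nM, most likely again only a limit.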

Compound 4, half-maximal inhibitory concentration: > 5000 nM
Compound 4 ended at the assay's limit; the forecaster's own chance of this, stated with the estimate: 80%; the middle value is on the limit's open side.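

Compound 3 and compound 4 both stop at a limit rather than a number, so no step between them can be read: the limit of > 5000 nM in this assay, at which 4 of the 4 values shown sit.

The compounds shown leave open whether 2H-tetrazol-5-yl in place of carboxy changes inhibition at all on either core.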